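The source may hold more compounds than are shown below. What is called first, only, known or untested is meant among the compounds shown, and "the series" means these compounds.

In a functional assay on PC-3 cells (Homo sapiens) for cytotoxicity (a higher number here means a weaker inhibitor, a lower number a stronger inhibitor), compound 1 (`COc1ccc(Cn2cc(/C=N\NC(=O)c3c[nH]c4ccccc34)c3ccccc32)cc1`) gives 14600 nM. Compound 2 (`COc1ccc(Cn2cc(/C=N\NC(=O)c3c[nH]c4ccccc34)c3cc(OC)ccc32)cc1`) gives 13600 nM and compound 3 (`COc1ccc(Cn2cc(/C=N\NC(=O)c3c[nH]c4ccc(Br)cc34)c3cc(OC)ccc32)cc1`) gives 28000 nM in the same measurement. The values of both lie within the scatter of the value of compound 1, so compound 1 is not separated from either of them.

Compound 4 (`COc1ccc(Cn2cc(/C=N\NC(=O)c3c[nH]c4ccccc34)c3ccc(F)cc32)cc1`) departs from compound 1 in one place: fluoro in place of hydrogen on an aromatic carbon. This is fluoro in place of hydrogen on an aromatic carbon of a six-membered aromatic ring of carbon only, part of a fused or bridged system of two rings, meta to a fused ring and para to a fused ring.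

For the measured compounds named here, two measured steps bear on this change. Methoxy in place of hydrogen on an aromatic carbon gave a 1.1-fold lower number from compound 1 to compound 2 (0.03 log units; within the scatter), and bromo in place of hydrogen on an aromatic carbon gave a 2.1-fold higher number from compound 2 to compound 3 (0.31 log units; beyond the scatter). Neither step introduces fluoro, so the data hold no direct measure of it. Going by the values given here, both steps are small, and the one starting from compound 1 stays within the scatter, so no step beyond the scatter is expected in this assay. The estimated change is a 1.0-fold lower number from compound 1 to compound 4 (0.02 log units; within the scatter), with no firm direction. Compound 4 is expected at 14000 nM, with an estimated range from 7000 nM to 28000 nM.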

Compound 4, half-maximal inhibitory concentration: 18400 nM
Compound 4: the middle estimate sits 1.3-fold (0.12 log units) below what was measured; the range from low to high includes it.
By their numbers in this assay, from the lowest: compounds 2, 1, 4 and 3 (each within the scatter of the next, the first and the last beyond it).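

In this assay, fluoro in place of hydrogen on an aromatic carbon, meta to a fused ring and para to a fused ring, gave a 1.3-fold higher number from compound 1 to compound 4 (0.10 log units; within the scatter) and so provides a direct measure of this change, one that does not separate compound 4 from compound 1. With a 1.1-fold lower number from compound 1 to compound 2 (0.03 log units; within the scatter) as well, two different replacements of hydrogen on the core of compound 1 have now stayed within the scatter, while a 2.1-fold higher number from compound 2 to compound 3 (0.31 log units; beyond the scatter) remains the only listed step beyond it, and that step is modest and made at a different aromatic carbon from compound 2. No measurement is available that could explain the small step to compound 4.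

The compounds shown leave open whether an amine, a carboxylic acid or a longer chain on this same aromatic carbon would also stay within the scatter of compound 1. They also leave open whether fluoro here would behave in the same way when combined with the bromo group of compound 3.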